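Dichlorophenyl swap on a chloro-substituted core

This account rests on a few compounds, and the source may have more. Where it says the series, first, only, none or still open, it means among the compounds named here.

Compound 1 `Cc1nc(N[C@@H]2C[C@H]3CC[C@@H]2C3)c2cc(-c3ccc(Cl)c(Cl)c3)ccc2n1` gives 56% in an ADME assay (Homo sapiens) for metabolic stability; a higher number here means that more of the compound is left, a lower number that less of the compound is left. Compound 2 `Cc1nc(N[C@@H]2C[C@H]3CC[C@@H]2C3)c2cc(-c3cc(Cl)cc(Cl)c3)ccc2n1` carries 3,5-dichlorophenyl in place of 3,4-dichlorophenyl on an aromatic carbon and gives 62% in this assay; the step of a number 6 percentage points higher from compound 1 to compound 2 (within the scatter) is small. Compound 3 `Clc1nc(N[C@@H]2C[C@H]3CC[C@@H]2C3)c2cc(-c3ccc(Cl)c(Cl)c3)ccc2n1` differs from compound 1 by chloro in place of methyl on an aromatic carbon. In this assay compound 3 gives 69%; the step of a number 13 percentage points higher from compound 1 to compound 3 (beyond the scatter) is the only one among these three beyond the scatter, and compound 3 stands highest of the three, though its gap to compound 2 is within the scatter.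

Compound 4 `Clc1cc(Cl)cc(-c2ccc3nc(Cl)nc(N[C@@H]4C[C@H]5CC[C@@H]4C5)c3c2)c1` is not yet measured in this assay. It differs from compound 3 by 3,5-dichlorophenyl in place of 3,4-dichlorophenyl on an aromatic carbon, the same change as between compound 1 and compound 2, made on the core of compound 3 rather than that of compound 1; the two cores differ by chloro in place of methyl on an aromatic carbon. The place of the change is described in the same words for both pairs.

For compound 4 the expected step is a number 5 percentage points higher from compound 3 to compound 4 (within the scatter), which rests on the earlier step of a number 6 percentage points higher from compound 1 to compound 2 (within the scatter) and on compound 3 giving 69%. Compound 4 is estimated at 74%, with a range from 62% to 86%.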

Compound 4, percent of the compound remaining: 85%
Compound 4: the middle estimate sits 11 percentage points below what was measured, within the range that was stated.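

On the core carrying chloro, 3,5-dichlorophenyl in place of 3,4-dichlorophenyl gives a number 16 percentage points higher from compound 3 to compound 4 (beyond the scatter) in this assay, and this step cannot be told apart from the one seen on the core carrying methyl: the same change on two cores in this assay, a number 6 percentage points higher (within the scatter) from compound 1 to compound 2 and a number 16 percentage points higher (beyond the scatter) from compound 3 to compound 4, 10 percentage points apart, within the scatter of two such steps

With 3,5-dichlorophenyl in place, chloro in place of methyl gives a number 23 percentage points higher from compound 2 to compound 4 (beyond the scatter) in this assay, and this step likewise cannot be told apart from its earlier counterpart: the same change on two cores in this assay, a number 13 percentage points higher (beyond the scatter) from compound 1 to compound 3 and a number 23 percentage points higher (beyond the scatter) from compound 2 to compound 4, 10 percentage points apart, within the scatter of two such steps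

Both changes therefore carry over between these two cores within the scatter, but this rests on a single set of four compounds and does not show that either step would hold on any other core.

The compounds shown cover only two dichlorophenyl patterns and only methyl or chloro on the shared core, with the same amine substituent throughout. From the compounds shown here alone, whether these steps persist with a methoxy group or a nitrile in place of chloro, or with a pyridyl ring in place of the dichlorophenyl, remains open.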